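The source may hold more compounds than are shown below. What is called first, only, known or untested is meant among the compounds shown, and "the series" means these compounds.

Measured compounds:
compound 1 `N#Cc1cccc(S(=O)(=O)Oc2ccc(-c3cncn3C3CCN(C(=O)c4ccc([N+](=O)[O-])cc4)CC3)cc2)c1`, 45 nM
compound 2 `CS(=O)(=O)c1ccc(C(=O)N2CCC(n3cncc3-c3ccc(OS(=O)(=O)c4cccc(C(=O)NC5CC5)c4)cc3)CC2)cc1`, 400 nM

Both were tested in an assay on HEK293 cells for antagonist activity at P2X purinoceptor 7 (Homo sapiens), read by fluorescence, with a stated time of 2 h; a higher number here means a weaker inhibitor, a lower number a stronger inhibitor. Compound 2 has the highest number of the two; compound 1 sits at a lower number, a gap beyond the usual scatter. Compound 3 `O=C(NC1CC1)c1cccc(S(=O)(=O)Oc2ccc(-c3cncn3C3CCN(C(=O)c4ccc([N+](=O)[O-])cc4)CC3)cc2)c1` arises from compound 2 by nitro in place of methylsulfonyl on an aromatic carbon. Going by the values given here, no measured pair isolates this change, so its size is uncertain. Since compound 1, which also carries nitro, gives 45 nM, a downward step a 2.7-fold lower number from compound 2 to compound 3 (0.43 log units; beyond the scatter) is expected. Compound 3 is estimated at 150 nM, within 50 nM to 450 nM.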

Compound 3, half-maximal inhibitory concentration: 152 nM
The estimate for compound 3 lay 1.0-fold (0.01 log units) below the measured number, and the stated range covers the measured number.
By their numbers in this assay, from the lowest: compound 1; then compound 3; then compound 2.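

In this assay, placing nitro instead of methylsulfonyl on this aromatic carbon gives a 2.6-fold lower number from compound 2 to compound 3 (0.42 log units; beyond the scatter), the first direct measure of this change. With nitro held fixed, cyclopropylcarbamoyl in place of cyano on the other aromatic ring gives a 3.4-fold higher number from compound 1 to compound 3 (0.53 log units; beyond the scatter), so a change at that second place also moves the number. No measured evidence here explains either step. Still open, from the compounds shown here alone, is how an amine or a carboxylic acid at the nitro position would compare, and whether the nitro-for-methylsulfonyl step would hold with cyano on the other ring.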